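The compounds below may be only part of what the source reports. "The series", "measured", "known", "first", "only" and "open" are said of these compounds alone.

Measured so far:
- compound 1 `COc1ccccc1-n1nncc1CN1C(=O)C2(C(C#N)=C(N)Oc3c2c2nc4ccccc4nc2c2ccccc32)c2ccccc21`: > 50000 nM
- compound 2 `CCOc1ccc(-n2nncc2CN2C(=O)C3(C(C#N)=C(N)Oc4c3c3nc5ccccc5nc3c3ccccc43)c3ccccc32)cc1`: 25200 nM
- compound 3 `COc1ccccc1-n1nncc1CN1C(=O)C2(C(C#N)=C(N)Oc3c(N)cc4nc5ccccc5nc4c32)c2ccccc21`: 37500 nM

All three compounds were run in a functional assay on A549 cells (Homo sapiens) for antiproliferative activity, read by MTT assay, with a stated time of 48 h; a higher number here means a weaker inhibitor, a lower number a stronger inhibitor. For compound 1 the value > 50000 nM is a limit of the assay, not a number. Compound 2 gives 25200 nM and compound 3 gives 37500 nM; these two numbers lie within the scatter of each other, so no order is drawn between them. Compound 2 differs from compound 1 by 4-ethoxyphenyl in place of 2-methoxyphenyl on an aromatic nitrogen, and the measured step is an at least 1.9-fold lower number from compound 1 to compound 2 (0.29 log units; that floor lies within the scatter); the floor of that step rests on (the limit of > 50000 nM in this assay, at which 1 of the 3 values shown sits), so the true size of the step is not fixed. Compound 3 and compound 1 carry different cores; the difference between the two cores is not broken down here.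

Compound 4 `CCOc1ccc(-n2nncc2CN2C(=O)C3(C(C#N)=C(N)Oc4c(N)cc5nc6ccccc6nc5c43)c3ccccc32)cc1` has not yet been measured. It differs from compound 3 by 4-ethoxyphenyl in place of 2-methoxyphenyl on an aromatic nitrogen, the same change at the same place as that from compound 1 to compound 2. In this assay, among the compounds with values here, a step of about a 1.9-fold lower number from compound 3 to compound 4 (0.27 log units; within the scatter) from compound 3 to compound 4 is expected, resting on the single earlier pair where the same change gave an at least 1.9-fold lower number from compound 1 to compound 2 (0.29 log units; that floor lies within the scatter) on the core of compound 1; with only one pair as guide, and that pair bounded by a limit, the expectation carries a wide range. Compound 4 is estimated at 20000 nM, with an expected range from 8000 nM to 50000 nM.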

Compound 4, half-maximal inhibitory concentration: > 50000 nM
Compound 4 was reported as a limit; the forecaster's own chance of this, stated with the estimate: 10%; at least 2.5-fold (0.39 log units) between middle value and limit.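

In this assay compound 4 gives > 50000 nM, which is a limit of the assay and not a number. Carrying 4-ethoxyphenyl in place of 2-methoxyphenyl onto the core of compound 3 gives an at least 1.3-fold higher number from compound 3 to compound 4 (0.12 log units; that floor lies within the scatter), and the comparison with the earlier pair reads: the same change on two cores in this assay, an at least 1.9-fold lower number (0.29 log units; that floor lies within the scatter) from compound 1 to compound 2 and an at least 1.3-fold higher number (0.12 log units; that floor lies within the scatter) from compound 3 to compound 4; the limit leaves it open whether they differ

The result therefore gives no support for a transfer of the lower number seen on the core of compound 1 to the core of compound 3, but it also does not show that the change behaves differently on the two cores, and the size of neither step is fixed: the limit of > 50000 nM in this assay, at which 2 of the 4 values shown sit.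

Only compound 2 and compound 3 carry numbers in this set, and they differ in more than one place, so the separate contributions of the core and of the group on the aromatic nitrogen stay unresolved. Going by these compounds, it remains open whether a phenyl group bearing a longer alkoxy chain, an amine or a carboxylic acid in place of the ethoxy group would give values clear of the limit on either core.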